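Removing the alkoxy cap from the shared chromone core

The compounds below may be only part of what the source reports. "The series", "measured", "known", "first", "only" and "open" are said of these compounds alone.

The three measured compounds were all tested in a functional assay on A549 cells (Homo sapiens) for cytotoxicity, with a stated time of 48 h; a lower number here means a stronger inhibitor, a higher number a weaker inhibitor:

Compound 1 `CCCC(=O)Oc1ccc2oc(/C=C/[S+](C)[O-])cc(=O)c2c1` — 2200 nM
Compound 2 `CCCCCOc1ccc2oc(/C=C/[S+](C)[O-])cc(=O)c2c1` — 1600 nM
Compound 3 `CC(C)Oc1ccc2oc(/C=C/[S+](C)[O-])cc(=O)c2c1` — 1500 nM

Compound 3 has the lowest of these three numbers, but its steps to the other two are small: a 1.5-fold lower number from compound 1 to compound 3 (0.17 log units; within the scatter) and a 1.1-fold lower number from compound 2 to compound 3 (0.03 log units; within the scatter), so on these data the three compounds cannot be told apart. The same holds for a 1.4-fold lower number from compound 1 to compound 2 (0.14 log units; within the scatter).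

Compound 4 `C[S+]([O-])/C=C/c1cc(=O)c2cc(O)ccc2o1` is the next step from compound 3. The change is hydrogen in place of isopropyl on an oxygen on an aromatic ring.

For the measured compounds named here, no measured step removes the group on this oxygen altogether; the steps on hand only swap one carbon group for another, and every one of them stayed within the scatter, whether the group was an ester or a plain chain, long or branched. That suggests this position tolerates change without much effect on the readout, yet leaving only a hydrogen is a larger departure than any tested. The expectation for this assay is therefore a step of a 1.7-fold higher number from compound 3 to compound 4 (0.22 log units; within the scatter), with wide uncertainty around it.

Compound 4 is estimated at 2500 nM, with a range from 800 nM to 8000 nM.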

Compound 4, half-maximal inhibitory concentration: 10500 nM
Beside the measured number, compound 4's estimate is 4.2-fold (0.62 log units) below it; measured number above the stated range.
By their numbers in this assay, from the lowest: compounds 3, 2 and 1 (each within the scatter of the next); then compound 4.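

On this oxygen, the earlier swaps between carbon groups gave no readable difference, but removing the group altogether does. In this assay, the change to hydroxy gives a 7.0-fold higher number from compound 3 to compound 4 (0.85 log units; beyond the scatter), a 6.6-fold higher number from compound 2 to compound 4 (0.82 log units; beyond the scatter) and a 4.8-fold higher number from compound 1 to compound 4 (0.68 log units; beyond the scatter), so all three steps lie beyond the scatter and compound 4 is the weakest of the four. Across these compounds, what separates the numbers is whether the oxygen carries a group at all, since an ester, a straight pentyl chain and a branched isopropyl group all land together, and nothing available explains why the free hydroxy compound gives the higher number.

The compounds shown leave open how small the group on this oxygen can be, for instance whether a single methyl group behaves like isopropyl or more like the bare hydrogen of compound 4. From the compounds shown here alone, it is also open whether a chain ending in an amine or a carboxylic acid would stay with compounds 1, 2 and 3 or move towards compound 4.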